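Benzofuran for Furan on a Nucleoside Scaffold

The source may report more compounds than this note shows. Statements on the series, on what has been measured and on what is new or still open speak of the compounds shown alone.

Compound 2 `Cc1ncnc2c1c(-c1ccoc1)cn2[C@@H]1O[C@H](CO)[C@@H](O)[C@H]1O` carries a furan-3-yl group on its core. In a functional assay on K562 cells (Homo sapiens), read by MTT assay, with a stated time of 72 h (a lower number here means a stronger inhibitor, a higher number a weaker inhibitor), compound 2 reaches only the limit of > 20000 nM. Compound 1 `Cc1ncnc2c1c(-c1cc3ccccc3o1)cn2[C@@H]1O[C@H](CO)[C@@H](O)[C@H]1O` is the same core changed by 1-benzofuran-2-yl in place of furan-3-yl on an aromatic carbon. In this assay compound 1 also reaches only the limit of > 20000 nM. The step that the two limits leave unreadable from compound 2 to compound 1 cannot be sized, since both values sit at the limit of > 20000 nM in this assay, at which 3 of the 3 values shown sit. Compound 3 `Cc1nc(N)c2c(-c3ccoc3)cn([C@@H]3O[C@H](CO)[C@@H](O)[C@H]3O)c2n1` has a different core; the difference between the two cores is not broken down here. In this assay compound 3 gives only the limit of > 20000 nM. Compound 4 `Cc1nc(N)c2c(-c3cc4ccccc4o3)cn([C@@H]3O[C@H](CO)[C@@H](O)[C@H]3O)c2n1` differs from compound 3 by 1-benzofuran-2-yl in place of furan-3-yl on an aromatic carbon, the same change at a place described in identical words. The step that the limit leaves unreadable from compound 3 to compound 4 is expected to be small, because the earlier step that the two limits leave unreadable from compound 2 to compound 1 was unreadable and all values sit at the limit of > 20000 nM in this assay, at which 3 of the 3 values shown sit. Compound 4 is therefore expected to give about 30000 nM, between 10000 nM and 100000 nM.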

Compound 4, half-maximal inhibitory concentration: 4990 nM
The estimate for compound 4 lay 6.0-fold (0.78 log units) above the measured number, outside the stated range (below it).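

In this assay, putting 1-benzofuran-2-yl in place of furan-3-yl on the core of compound 3 gives an at least 4.0-fold lower number from compound 3 to compound 4 (0.60 log units; beyond the scatter); the true size may be larger, since compound 3 gives only a limit. The same change on the other core cannot be sized, because compound 2 and compound 1 both stop at a limit of the assay: the limit of > 20000 nM in this assay, at which 3 of the 4 values shown sit. So the change clearly lowers the number on one core, but the data neither show that this effect carries over to the other core nor rule it out.

As far as these compounds go, it remains open whether a phenyl group or an amine at the same place would lower the number on either core. Which part of the core difference matters also remains open.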